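The source may hold more compounds than are shown below. What is called first, only, known or untested is meant among the compounds shown, and "the series" means these compounds.

In a functional assay on HeLa cells (Homo sapiens) for antiproliferative activity, read by sulforhodamine B assay (a lower number here means a stronger inhibitor of growth, a higher number a weaker inhibitor of growth), compound 3 (`C=CC[C@@H]1O[C@H](COCc2ccccc2)[C@@H](OCc2ccccc2)[C@H](OCc2ccccc2)[C@H]1O`) gives 26200 nM and stands within the scatter of compound 1 (`CC[C@@H]1O[C@H](COCc2ccccc2)[C@@H](OCc2ccccc2)[C@H](OCc2ccccc2)[C@H]1O`) with 19800 nM and of compound 2 (`CCC[C@@H]1O[C@H](COCc2ccccc2)[C@@H](OCc2ccccc2)[C@H](OCc2ccccc2)[C@H]1O`) with 18900 nM on the same scale. The move to compound 4 (`OC[C@@H]1O[C@H](COCc2ccccc2)[C@@H](OCc2ccccc2)[C@H](OCc2ccccc2)[C@H]1O`) is hydroxy in place of vinyl on a saturated chain carbon bound to a saturated ring carbon and puts hydroxy in place of vinyl on a saturated chain carbon bound to a saturated ring carbon. The measured steps at this place are a 1.0-fold lower number from compound 1 to compound 2 (0.02 log units; within the scatter) and a 1.3-fold higher number from compound 1 to compound 3 (0.12 log units; within the scatter) and a 1.4-fold higher number from compound 2 to compound 3 (0.14 log units; within the scatter) and all three are small. Going by the values given here, none of them brings in a hydroxy, so the data give no direct precedent. No change beyond the scatter is expected, and the expected size is a 1.2-fold lower number from compound 3 to compound 4 (0.08 log units; within the scatter) in the estimate. Compound 4 is estimated at 22000 nM with an expected range from 10000 nM to 45000 nM for this compound.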

Compound 4, concentration for 50% growth inhibition: 25800 nM
The estimate for compound 4 lay 1.2-fold (0.07 log units) below the measured number, and the stated range covers the measured number.
By their numbers in this assay, from the lowest: compounds 2, 1, 4 and 3 (each within the scatter of the next).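

In this assay, a hydroxy on this saturated chain carbon bound to a saturated ring carbon reads the same as the carbon groups it replaces: vinyl (a 1.0-fold lower number from compound 3 to compound 4 (0.01 log units; within the scatter)), ethyl (a 1.4-fold higher number from compound 2 to compound 4 (0.14 log units; within the scatter)) and methyl (a 1.3-fold higher number from compound 1 to compound 4 (0.11 log units; within the scatter)). The position, so far shown holding only carbon groups, thus also accepts a hydrogen-bond donor and acceptor with no change beyond the scatter across these four compounds. Nothing available explains why this position shows so little change. On these data alone, whether an amine, a carboxylic acid or a longer chain here would also stay within the scatter remains open.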